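Purine series: chloro replacing the amino group on the core

The source may report more compounds than this note shows. Statements on the series, on what has been measured and on what is new or still open speak of the compounds shown alone.

Going by the values given here, compound 2 `Nc1nc(Cl)c2ncn(Cc3ccc(CCl)cc3)c2n1` gives 75900 nM in a functional assay on A549 cells (Homo sapiens) for cytotoxicity, read by sulforhodamine B assay, with a stated time of 48 h (a higher number here means a weaker inhibitor of growth, a lower number a stronger inhibitor of growth), the highest of the two numbers so far; the nearest is compound 1 `ClCc1ccc(Cn2cnc3c(Cl)ncnc32)cc1` with 18200 nM. Among the compounds with values here, the one step measured so far, a 4.2-fold higher number from compound 1 to compound 2 (0.62 log units; beyond the scatter), adds an amino group on an aromatic carbon. Compound 3 `ClCc1ccc(Cn2cnc3c(Cl)nc(Cl)nc32)cc1` differs from compound 2 by chloro in place of amino on an aromatic carbon, on an aromatic carbon between two ring nitrogen atoms. Within the data shown here, the measured step bears on this only in part: the amino group whose arrival raised the number is lost, but no measured pair shows what chloro does in its place. The expected step of a 3.8-fold lower number from compound 2 to compound 3 (0.58 log units; beyond the scatter) therefore leans toward a lower number in this assay, roughly undoing the rise of a 4.2-fold higher number from compound 1 to compound 2 (0.62 log units; beyond the scatter), with wide uncertainty. Compound 3 is estimated at 20000 nM, with a range from 6000 nM to 65000 nM.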

Compound 3, concentration for total growth inhibition: 37200 nM
Compound 3: the middle estimate sits 1.9-fold (0.27 log units) below what was measured; measured number inside the range.
By their numbers in this assay, from the lowest: compound 1; then compound 3; then compound 2.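

At the aromatic carbon between two ring nitrogen atoms, hydrogen, amino and chloro can now be compared in this assay. Chloro in place of amino gives a 2.0-fold lower number from compound 2 to compound 3 (0.31 log units; beyond the scatter) and so recovers only part of the rise seen with amino, while chloro in place of hydrogen gives a 2.0-fold higher number from compound 1 to compound 3 (0.31 log units; beyond the scatter) and places chloro in the middle of the three, with hydrogen in compound 1 still giving the lowest number. No available evidence bears on why the three groups fall in this order. From the compounds shown here alone, whether a methoxy or methylamino group at this carbon would give a number lower than hydrogen remains open. Also open, going by these compounds, is whether the same order would hold if a hydroxymethyl group replaced the chloromethyl group shared by all three compounds.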